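The source may report more compounds than this note shows. Statements on the series, on what has been measured and on what is new or still open speak of the compounds shown alone.

Measured so far in an assay on IM-9 cells for binding affinity to Substance-P receptor (Homo sapiens); on this read-out lower numbers stand for stronger inhibition and higher numbers for weaker inhibition:
compound 1 `CCN(Cc1ccccc1OC)C(=O)c1c(-c2ccccc2C)c2ccccc2c(=O)n1C` gives 34 nM;
compound 2 `COc1ccccc1CN(C)C(=O)Nc1c(-c2ccccc2)c2cc(C)c(C)cc2c(=O)n1C` gives 23 nM;
compound 3 `CN(Cc1ccccc1Cl)C(=O)Nc1c(-c2ccc(F)cc2)c2ccccc2c(=O)n1C` gives 480 nM.

Compound 2 has the lowest number of the three, yet compound 1 lies so close that the two cannot be told apart; compound 3 stands well beyond the scatter with a clearly higher number. Compound 4 `Cc1cccc(NC(=O)Nc2c(-c3ccccc3)c3cc(C)c(C)cc3c(=O)n2C)c1` has not been measured. It differs from compound 2 in one place: (3-methylphenyl)amino in place of (2-methoxybenzyl)(methyl)amino on a carbonyl carbon. The entering group is smaller and brings a hydrogen-bond donor where the leaving group carried a hydrogen-bond acceptor. Among the compounds with values here, no measured pair shows this exact change, so the expectation rests on compound 2 alone. In this assay a rise in the number, toward weaker binding and beyond the scatter, is expected: a 13-fold higher number from compound 2 to compound 4 (1.12 log units; beyond the scatter). Compound 4 is estimated at 300 nM, with a range from 50 nM to 2000 nM.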

Compound 4, half-maximal inhibitory concentration: 840 nM
Beside the measured number, compound 4's estimate is 2.8-fold (0.45 log units) below it, within the range that was stated.
By their numbers in this assay, from the lowest: compounds 2 and 1 (each within the scatter of the next); then compounds 3 and 4 (each within the scatter of the next).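

In this assay, the group on this carbonyl carbon clearly matters: (3-methylphenyl)amino in place of (2-methoxybenzyl)(methyl)amino is a large change, beyond the scatter (a 37-fold higher number from compound 2 to compound 4 (1.56 log units; beyond the scatter)). Within the data shown here, no earlier pair differed in only one place, so this is the first direct reading of any position. Nothing shown explains the rise.

On these data alone, the swap alters the group's size and its hydrogen-bond donor and acceptor counts together, so the part that matters stays open. A (3-methylphenyl)(methyl)amino or benzylamino group on the same carbonyl carbon would help separate these changes.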